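The source may report more compounds than this note shows. Statements on the series, on what has been measured and on what is new or still open speak of the compounds shown alone.

Measured so far in an assay on isolated protein for inhibition of aldehyde dehydrogenase 1A1 (Homo sapiens), read by spectrophotometry, tested at 10 uM; a higher number here means more inhibition at the concentration tested (going by the name of the read-out), a lower number less inhibition:
compound 1 `Cc1cccc(Cn2c(CN3CCN(C(=O)C4CCCCC4)CC3)nc3ccccc32)c1` gives 31.9%
compound 2 `CC(C)Cn1c(CN2CCN(C(=O)C3CC3)CC2)nc2ccccc21` gives 13.1%
compound 3 `CC(C)=CCn1c(CN2CCN(C(=O)C3CC3)CC2)nc2ccccc21` gives 74.3%

Compound 1 stands second highest of the three numbers: compound 2 lies lower and compound 3 lies higher, both gaps beyond the usual scatter. Going by the values given here, the only single-point step among the measured compounds is a number 61.2 percentage points higher from compound 2 to compound 3 (beyond the scatter), and it concerns the group on a saturated chain carbon bound to an aromatic nitrogen, a different place from the one that changes here.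

Compound 4 `Cc1cccc(Cn2c(CN3CCN(C(=O)c4cccnc4)CC3)nc3ccccc32)c1` differs from compound 1 at the carbonyl carbon only: pyridin-3-yl in place of cyclohexyl on a carbonyl carbon. Among the compounds with values here, no measured pair in this set alters the group on the carbonyl carbon, so the one known step does not bear directly on this change, large as it is at its own position. With no guide in either direction, the working assumption is that compound 4 stays near compound 1 in this assay, and the expected step is a number 1.9 percentage points lower from compound 1 to compound 4 (within the scatter), which is none beyond the scatter. Compound 4 is accordingly expected to give about 30% in this assay, with a range from 10% to 55% to reflect the absence of any comparable measured step.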

Compound 4, a percentage reported as inhibition, at one concentration (the size of the read-out at that concentration, not a potency): 24.5%
Beside the measured number, compound 4's estimate is 5.5 percentage points above it; the range from low to high includes it.
By their numbers in this assay, from the lowest: compound 2; then compounds 4 and 1 (each within the scatter of the next); then compound 3.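

In this assay, going by these compounds alone, the change on the carbonyl carbon, read here for the first time, is a number 7.4 percentage points lower from compound 1 to compound 4 (within the scatter), so an aromatic ring with one nitrogen and one hydrogen-bond acceptor takes the place of an all-carbon non-aromatic ring without a shift beyond the scatter. This holds for one pair only, on the core of compound 1, and it contrasts with the other single-point step in the series, a number 61.2 percentage points higher from compound 2 to compound 3 (beyond the scatter), which lies beyond the scatter at the group on a saturated chain carbon bound to an aromatic nitrogen. Nothing at hand gives a reason for either outcome.

Within the data shown here, still open is whether the carbonyl position stays as flat when the chain of compound 3 sits on the ring nitrogen, since the only pair at the carbonyl carbon has a low-scoring partner on both sides. Also open, on these data alone, is how phenyl, pyridin-4-yl or a ring carrying an amine or a carboxylic acid would read on the carbonyl carbon.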